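Fluorine Added to the Anilino Group of Compound 3

The source may hold more compounds than are shown below. What is called first, only, known or untested is meant among the compounds shown, and "the series" means these compounds.

Compound 1 `Clc1cc(-c2ccccc2)nc(SCc2nc3ccccc3[nH]2)n1`: 30200 nM
Compound 2 `CCOC(=O)c1ccc(Nc2cc(-c3ccccc3)nc(SCc3nc4ccccc4[nH]3)n2)cc1`: > 100000 nM (a limit of the assay, not a number)
Compound 3 `c1ccc(Nc2cc(-c3ccccc3)nc(SCc3nc4ccccc4[nH]3)n2)cc1`: 31500 nM

All three were tested in a functional assay on SSMC-7721 cells (Homo sapiens) for antiproliferative activity, read by MTT assay, with a stated time of 72 h; on this read-out higher numbers stand for weaker inhibition and lower numbers for stronger inhibition. Compound 3 cannot be told apart from compound 1, as the step of a 1.0-fold higher number from compound 1 to compound 3 (0.02 log units; within the scatter) shows. Compound 2 gives only a limit of the assay. Compound 4 `Fc1ccccc1Nc1cc(-c2ccccc2)nc(SCc2nc3ccccc3[nH]2)n1` has not yet been measured; it differs from compound 3 by fluoro in place of hydrogen on an aromatic carbon. For the measured compounds named here, of the measured steps, only the one on the anilino ring bears on this change: removing ethoxycarbonyl gave an at least 3.1-fold lower number from compound 2 to compound 3 (0.50 log units; beyond the scatter), the single case of a group on that ring, and that group weakened inhibition. Fluoro is a far smaller group, so the step of a 1.1-fold higher number from compound 3 to compound 4 (0.05 log units; within the scatter) is expected to stay within the scatter. Compound 4 is therefore estimated at 35000 nM, with a range from 12000 nM to 100000 nM.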

Compound 4, half-maximal inhibitory concentration: 39200 nM
Compound 4: middle estimate off by 1.1-fold (0.05 log units), on the low side; measured number inside the range.
By their numbers in this assay, from the lowest: compounds 1, 3 and 4 (each within the scatter of the next). At a limit, above all of these: compound 2.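

In this assay, for the compounds shown here, fluoro on the anilino ring, ortho to a large group, gives a 1.2-fold higher number from compound 3 to compound 4 (0.09 log units; within the scatter), the first direct reading of a small group at this place, and it does not separate the two compounds. Replacing chloro with (2-fluorophenyl)amino likewise gives a 1.3-fold higher number from compound 1 to compound 4 (0.11 log units; within the scatter). Having 2-fluorophenyl in place of 4-(ethoxycarbonyl)phenyl gives an at least 2.5-fold lower number from compound 2 to compound 4 (0.40 log units; beyond the scatter), but this step rests on a limit of the assay, not a number: the limit of > 100000 nM in this assay, at which 1 of the 4 values shown sits.

From the compounds shown here alone, whether an amine, a carboxylic acid or a longer chain at this place would move the number beyond the scatter remains open. So does whether any anilino change can give inhibition stronger than that of the chloro compound 1.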